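The source may report more compounds than this note shows. Statements on the series, on what has been measured and on what is new or still open speak of the compounds shown alone.

Measured so far in a functional assay on RS4-11 cells (Homo sapiens) for inhibition, read by CCK-8 assay, with a stated time of 48 h, tested at 20 uM; a higher number here means more inhibition of growth at the concentration tested, a lower number less inhibition of growth:

- compound 1 `N#C/C(=C\c1ccccc1OS(=O)(=O)c1ccccc1[N+](=O)[O-])C(=O)Nc1nnc(Cc2cccc(F)c2)s1` gives 68%
- compound 2 `N#C/C(=C\c1ccccc1OS(=O)(=O)c1ccc([N+](=O)[O-])cc1)C(=O)Nc1nnc(Cc2ccc(Cl)cc2)s1` gives 66%

Compound 2 stands level with compound 1, as their two values lie within the scatter of each other. Compound 3 `N#C/C(=C\c1ccccc1OS(=O)(=O)c1ccccc1[N+](=O)[O-])C(=O)Nc1nnc(Cc2ccc(Cl)cc2)s1` follows from compound 2 through 2-nitrophenyl in place of 4-nitrophenyl on a sulfonyl sulfur and so carries 2-nitrophenyl in place of 4-nitrophenyl on a sulfonyl sulfur. For the measured compounds named here, no measured pair isolates this change, so any expectation for it remains weakly supported. The 2-nitrophenyl group already occurs in compound 1, which gives 68% in this assay despite differing from compound 3 elsewhere. No shift beyond the scatter is expected in either direction. The expected change is a number 1 percentage points higher from compound 2 to compound 3 (within the scatter) and would stay within the scatter. The estimate for compound 3 is 67%, with an expected range from 52% to 80%.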

Compound 3, percent growth inhibition at one concentration: 65%
Estimate against measurement, compound 3: 2 percentage points above; the range from low to high includes it.
By their numbers in this assay, from the lowest: compounds 3, 2 and 1 (each within the scatter of the next).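

In this assay, for the compounds shown here, the first isolated reading of 2-nitrophenyl in place of 4-nitrophenyl on the sulfonyl sulfur gives a number 1 percentage points lower from compound 2 to compound 3 (within the scatter), so the two nitrophenyl arrangements cannot be told apart at this position with the 4-chlorophenyl group held fixed. At the other end of the molecule, 4-chlorophenyl in place of 3-fluorophenyl on the saturated chain carbon bound to an aromatic carbon gives a number 3 percentage points lower from compound 1 to compound 3 (within the scatter), so this exchange likewise leaves the reading unseparated with the 2-nitrophenyl group held fixed. No measurement bears on why these compounds read alike.

Open, going by these compounds, is whether the nitro group matters at all: a plain phenyl or an aminophenyl on the sulfonyl sulfur would test this. Also open, on these data alone, is whether a full concentration series would separate compounds that read alike at one concentration.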